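Thiophene-fused cores: cytotoxicity limit holds across two sulfones

A few compounds are considered here, and "the series" means these few. Any claim that something is new, unique, unknown or untested is made for them only; others in the source may bear on it.

Compounds with values so far:
compound 1, `COc1ccc(-c2nc(C(C)(C)S(=O)(=O)c3cccc(Cl)c3)nc3ccsc23)cn1`, gives > 50000 nM;
compound 2, `O=S(=O)(Cc1nc(-c2ccncc2)c2sccc2n1)c1cccc(Cl)c1`, gives > 50000 nM.

Both compounds were tested in an ADME assay on cells (Homo sapiens) for cytotoxicity, read by resazurin assay, with a stated time of 5 days; on this read-out higher numbers stand for lower toxicity in this test and lower numbers for higher toxicity in this test. For compound 1 the value > 50000 nM is a limit of the assay, not a number. For compound 2 the value > 50000 nM is likewise a limit. Among the measured compounds shown here, compound 2 therefore stands at the limit of > 50000 nM in this assay, at which 2 of the 2 values shown sit, so no step between measured compounds can be sized here.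

Compound 3, `COc1ccc(Nc2nc(CS(=O)(=O)c3cccc(Cl)c3)nc3ccsc23)cc1`, has not yet been measured. It differs from compound 2 in one place: (4-methoxyphenyl)amino in place of pyridin-4-yl on an aromatic carbon. Because both shown values sit at the limit of > 50000 nM in this assay, at which 2 of the 2 values shown sit, the step from compound 2 to compound 3 is expected to be none beyond the scatter, with the assay again likely to report only a limit. Compound 3 is estimated at 60000 nM, within 20000 nM to 200000 nM, meaning an expected step that the limit leaves unreadable from compound 2 to compound 3.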

Compound 3, half-maximal cytotoxic concentration: 60000 nM
Compound 3: the middle estimate sits on the measured number at the digits printed, and the stated range covers the measured number.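

In this assay compound 2 gives > 50000 nM, which is a limit and not a number, so no step to compound 3 can be read: the limit of > 50000 nM in this assay, at which 2 of the 3 values shown sit.

The compounds shown leave open what size of step (4-methoxyphenyl)amino in place of pyridin-4-yl brings.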